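The source may report more compounds than this note shows. Statements on the series, on what has been measured and on what is new or still open speak of the compounds shown alone.

Going by the values given here, compound 3 `COc1cc(/C=C/C(=O)c2cccc(-n3cc(-c4ccccc4)[nH]c3=O)c2)cc(OC)c1OC` gives 1130 nM in a functional assay on HCT-15 cells (Homo sapiens) for inhibition (a higher number here means a weaker inhibitor of growth, a lower number a stronger inhibitor of growth), the lowest of the three numbers measured so far. Compound 2 `O=C(/C=C/c1cccc(O)c1)c1cccc(-n2cc(-c3ccccc3)[nH]c2=O)c1` gives 3100 nM in this assay, and compound 1 `COc1cc(/C=C/C(=O)c2cccc(-n3cc(-c4ccc(Cl)cc4)[nH]c3=O)c2)cc(OC)c1OC` gives 3850 nM. Among the compounds with values here, the only measured step that touches the phenyl on the five-membered aromatic ring with 2 nitrogen is a 3.4-fold lower number from compound 1 to compound 3 (0.53 log units; beyond the scatter). Compound 4 `COc1cc(/C=C/C(=O)c2cccc(-n3cc(-c4cc(OC)c(OC)c(OC)c4)[nH]c3=O)c2)cc(OC)c1OC` differs from compound 3 by 3,4,5-trimethoxyphenyl in place of phenyl on an aromatic carbon. Within the data shown here, no measured step places a methoxy-bearing group at that position, so the direction of this change rests on little; the one substituent tried there, the chloro of compound 1, gave a higher number. A modest rise, expected as a 1.6-fold higher number from compound 3 to compound 4 (0.20 log units; within the scatter), seems the more likely outcome. Compound 4 is therefore expected to give about 1800 nM in this assay, within the range 500 nM to 6500 nM.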

Compound 4, concentration for 50% growth inhibition: 1890 nM
Beside the measured number, compound 4's estimate is 1.1-fold (0.02 log units) below it, within the range that was stated.
By their numbers in this assay, from the lowest: compounds 3, 4, 2 and 1 (each within the scatter of the next, the first and the last beyond it).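

In this assay, the position on the five-membered aromatic ring with 2 nitrogen takes the much larger 3,4,5-trimethoxyphenyl in place of phenyl with a 1.7-fold higher number from compound 3 to compound 4 (0.22 log units; within the scatter), so the added methoxy groups leave the number within the scatter. Measured against the 4-chlorophenyl group, the same change gives a 2.0-fold lower number from compound 1 to compound 4 (0.31 log units; beyond the scatter), which sets compound 1 apart from both compound 3 and compound 4 at this position. Nothing measured here explains these differences. The compounds shown leave open whether a single methoxy group on this phenyl would behave like the 3,4,5-trimethoxyphenyl group. They also leave open how an amine or a carboxylic acid on that ring would fare.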